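The source may hold more compounds than are shown below. What is called first, only, known or untested is meant among the compounds shown, and "the series" means these compounds.

Measured in a functional assay on A549 cells (Homo sapiens), read by MTT assay, with a stated time of 72 h; a higher number here means a weaker inhibitor, a lower number a stronger inhibitor:
Compound 1 `C#Cc1cn([C@@H]2O[C@H](CO)[C@@H](O)[C@H]2O)c2ncnc(SC)c12`: 140 nM
Compound 2 `CN(C)c1ncnc2c1c(-c1ccsc1)cn2[C@@H]1O[C@H](CO)[C@@H](O)[C@H]1O`: > 20000 nM
Compound 3 `CN(C)c1ncnc2c1c(-c1cc3ccccc3o1)cn2[C@@H]1O[C@H](CO)[C@@H](O)[C@H]1O`: > 20000 nM

Compound 3 stands only at a limit of this assay, not at a number, and its value is > 20000 nM. Compound 2 is likewise reported only as a limit, and its value is > 20000 nM. Together these two make up (the limit of > 20000 nM in this assay, at which 2 of the 3 values shown sit).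

The next compound, compound 4 `C#Cc1cn([C@@H]2O[C@H](CO)[C@@H](O)[C@H]2O)c2ncnc(N(C)C)c12`, has ethynyl in place of 1-benzofuran-2-yl on an aromatic carbon. Among the measured compounds shown here, the one measured step, a step that the two limits leave unreadable from compound 2 to compound 3, has no readable size, so it gives no guide to how much a change at this place matters. The only other clue is that ethynyl is also carried by compound 1, which gives 140 nM. However, compound 1 differs from compound 4 elsewhere, and no measured step shows what that difference is worth.

A step toward stronger inhibition in this assay is therefore expected, though its size is poorly defined and compound 4 could still remain at the limit. The expected change is an at least 13-fold lower number from compound 3 to compound 4 (1.12 log units; beyond the scatter). For compound 4 the estimated value is 1500 nM, with an expected range from 150 nM to 20000 nM.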

Compound 4, half-maximal inhibitory concentration: 390 nM
Compound 4: the middle estimate sits 3.8-fold (0.59 log units) above what was measured, within the range that was stated.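

In this assay, the group on this aromatic carbon of the five-membered ring now shows a readable effect with dimethylamino held constant: ethynyl in place of 1-benzofuran-2-yl gives an at least 51-fold lower number from compound 3 to compound 4 (1.70 log units; beyond the scatter), and ethynyl in place of thiophen-3-yl gives an at least 51-fold lower number from compound 2 to compound 4 (1.70 log units; beyond the scatter). Both sizes are minimum sizes only, as compound 2 and compound 3 each stand at a limit and not at a number: the limit of > 20000 nM in this assay, at which 2 of the 4 values shown sit. Among the compounds shown here, with ethynyl held constant, the other substituted aromatic carbon can also be read for the first time, and dimethylamino in place of methylsulfanyl gives a 2.8-fold higher number from compound 1 to compound 4 (0.44 log units; beyond the scatter), a modest step that is much smaller than the minimum size of either step at the ethynyl position.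

The compounds shown leave open whether the triple bond itself matters or whether any small group would serve on this carbon, a question that ethyl or ethenyl would address. They also leave open how far the other position tolerates change, for instance with methoxy or methylamino in place of dimethylamino.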